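The compounds below may be only part of what the source reports. "The series", "measured", "known", "first", "only" and "open" are said of these compounds alone.

Measured in a functional assay on OVCAR-8 cells (Homo sapiens) for inhibition, read by sulforhodamine B assay, with a stated time of 48 h; a higher number here means a weaker inhibitor of growth, a lower number a stronger inhibitor of growth:
- compound 1 `COc1ccc(-c2[nH]c3ccccc3c2/C=C(\C#N)S(=O)(=O)c2ccccc2)cc1` gives 1300 nM
- compound 2 `CC(=O)/C(=C\c1c(-c2ccccc2)[nH]c2ccccc12)S(=O)(=O)c1ccccc1` gives 2500 nM
- compound 3 `COc1ccc2[nH]c(-c3ccccc3)c(/C=C(\C#N)S(=O)(=O)c3ccccc3)c2c1` gives 7800 nM

Compound 3 carries the highest number of the three in this assay; its number stands above that of compound 2 and further above that of compound 1, both gaps beyond the scatter. Within the data shown here, no pair here differs in a single place, so no measured step exists.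

Compound 4 `N#C/C(=C\c1c(-c2ccccc2)[nH]c2ccccc12)S(=O)(=O)c1ccccc1` follows from compound 3 by hydrogen in place of methoxy on an aromatic carbon. Among the measured compounds shown here, the three compounds give no single-change step in this assay to rest on. For compound 4 a modest move to a lower number is expected, without strong support, giving an estimated step of a 2.2-fold lower number from compound 3 to compound 4 (0.35 log units; beyond the scatter). Compound 4 is accordingly estimated at 3500 nM, within a range from 1000 nM to 10000 nM.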

Compound 4, concentration for 50% growth inhibition: 6000 nM
Compound 4: the middle estimate sits 1.7-fold (0.23 log units) below what was measured; low and high end bracket the measured number.
By their numbers in this assay, from the lowest: compounds 1 and 2 (each within the scatter of the next); then compounds 4 and 3 (each within the scatter of the next).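

In this assay, hydrogen in place of methoxy on the aromatic carbon of the fused system changes little (a 1.3-fold lower number from compound 3 to compound 4 (0.11 log units; within the scatter)), so the methoxy at this position is not needed for the growth inhibition seen here. The same exchange on an aromatic carbon elsewhere in the structure gives a step beyond the scatter (a 4.6-fold higher number from compound 1 to compound 4 (0.66 log units; beyond the scatter)), as does cyano in place of acetyl on the double-bonded chain carbon (a 2.4-fold higher number from compound 2 to compound 4 (0.38 log units; beyond the scatter)). Nothing at hand accounts for these differences.

Still open, going by these compounds, is whether an amine or a carboxylic acid on the aromatic carbon of the fused system would shift the number. Also open, on these data alone, is whether an ester in place of the cyano would do so.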